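Homologated aryl ether at the saturated ether position

The source may report more compounds than this note shows. Statements on the series, on what has been measured and on what is new or still open speak of the compounds shown alone.

Compound 2 `Cc1nn(-c2ncnc3nc[nH]c23)c2c1C(OCc1ccc(F)cc1)CC(=O)N2` gives 1 nM in a functional assay on HEK293 cells for agonist activity at G-protein coupled receptor 39 (Homo sapiens), read by scintillation proximity assay and inositol phosphate accumulation, with a stated time of 75 min, in the presence of a further agent that is not named here (a lower number here means that less compound is needed, a higher number that more compound is needed for the effect), the lowest of the two numbers; compound 1 `Cc1noc(C)c1COC1CC(=O)Nc2c1c(C)nn2-c1ncnc2nc[nH]c12` gives 5 nM, and the step of a 5.0-fold lower number from compound 1 to compound 2 (0.70 log units; beyond the scatter) was modest but beyond the scatter. Compound 3 `COc1ccc(CCOC2CC(=O)Nc3c2c(C)nn3-c2ncnc3nc[nH]c23)cc1` carries the change (4-methoxybenzyl in place of 4-fluorophenyl on a saturated chain carbon bound to an oxygen on a saturated carbon). Among the compounds with values here, no measured step covers this change; the single step from compound 1 to compound 2 only shows that the group at this place matters. Since compound 2 already sits lowest, compound 3 is expected to shift by a 4.0-fold higher number from compound 2 to compound 3 (0.60 log units; beyond the scatter), most likely to a somewhat higher number, estimated at 4 nM with a range of 1 nM to 15 nM.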

Compound 3, half-maximal effective concentration: 2 nM
The estimate for compound 3 lay 2.0-fold (0.30 log units) above the measured number; the range from low to high includes it.
By their numbers in this assay, from the lowest: compounds 2 and 3 (each within the scatter of the next); then compound 1.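

In this assay, the position takes 2-(4-methoxyphenyl)ethyl as readily as 4-fluorobenzyl, with a 2.0-fold higher number from compound 2 to compound 3 (0.30 log units; within the scatter). The step of a 2.5-fold lower number from compound 1 to compound 3 (0.40 log units; beyond the scatter) shows that a second group with a six-membered aromatic ring of carbon only also stands clear of the 3,5-dimethyl-1,2-oxazol-4-yl group. Nothing at hand explains either step.

From the compounds shown here alone, the chain and the ring substituent change together here, and their separate contributions stay open. Going by these compounds, it also remains open how an amine or a carboxylic acid on the aromatic ring would fare at this place.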